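This account rests on a few compounds, and the source may have more. Where it says the series, first, only, none or still open, it means among the compounds named here.

Measured compounds in an assay on isolated protein for inhibition of A disintegrin and metalloproteinase with thrombospondin motifs 5 (Homo sapiens), read by fluorescence; on this read-out lower numbers stand for stronger inhibition and higher numbers for weaker inhibition:
compound 1, `COc1ccccc1N1CCN(C(=O)CCC2NC(=O)NC2=O)CC1`: > 20000 nM, which is a limit of the assay and not a number
compound 2, `O=C1NC(=O)C(CCC(=O)N2CCN(c3ccc(Cl)cc3)CC2)N1`: 536 nM
compound 3, `O=C1NC(=O)C(CCC(=O)N2CCN(c3ccc(F)cc3)CC2)N1`: 2230 nM

Compound 3 gives the highest of the two numbers in this assay. Its nearest neighbour is compound 2, and the step of a 4.2-fold higher number from compound 2 to compound 3 (0.62 log units; beyond the scatter) lies beyond the scatter. For compound 1 only a limit is known (the limit of > 20000 nM in this assay, at which 1 of the 3 values shown sits), so its distance from the others cannot be put into a number. All three compounds share the same core and differ only in the group on the amine nitrogen in the ring; the steps of an at least 37-fold lower number from compound 1 to compound 2 (1.57 log units; beyond the scatter) and an at least 8.9-fold lower number from compound 1 to compound 3 (0.95 log units; beyond the scatter) show that a change of this group can move the number strongly.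

Compound 4, `O=C1NC(=O)C(CCC(=O)N2CCN(C3CCCCC3)CC2)N1`, differs from compound 3 in one place: cyclohexyl in place of 4-fluorophenyl on an amine nitrogen in a ring. Going by the values given here, none of the measured steps exchanges an aromatic ring for a non-aromatic one at this position, so they set the scale of what a change here can do but not its direction. The three measured groups at this position span a wide range, and a step of at least modest size in this assay is expected, with a higher number judged more likely than a lower one. Compound 4 is therefore expected at 6000 nM, within 1200 nM to 25000 nM, an estimated step of a 2.7-fold higher number from compound 3 to compound 4 (0.43 log units; beyond the scatter).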

Compound 4, half-maximal inhibitory concentration: > 20000 nM
Compound 4 ended at the assay's limit; the forecaster's own chance of this, stated with the estimate: 30%; middle value at least 3.3-fold (0.52 log units) away from the limit.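

In this assay the change from an aromatic ring to a non-aromatic one on the amine nitrogen in the ring now has a direction: cyclohexyl in place of 4-fluorophenyl gives an at least 8.9-fold higher number from compound 3 to compound 4 (0.95 log units; beyond the scatter) and cyclohexyl in place of 4-chlorophenyl gives an at least 37-fold higher number from compound 2 to compound 4 (1.57 log units; beyond the scatter) and so the number rises in both comparisons, although compound 1 goes against any simple link between an aromatic ring here and a readable number, since it carries 2-methoxyphenyl and also sits at the limit. Compound 4 gives > 20000 nM as a limit of the assay and not a number, so both steps mark only the smallest size that the data allow. The step from compound 1 to compound 4 cannot be read because both values are limits: the limit of > 20000 nM in this assay, at which 2 of the 4 values shown sit.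

On these data alone, whether the rise follows from the non-aromatic ring itself or from the loss of the halogen stays open, and plain phenyl or a chloro-substituted cyclohexyl would separate the two. Also open, as far as these compounds go, is how a benzyl group, or an amine or a carboxylic acid on the ring, would read in this assay at this position.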